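The source may report more compounds than this note shows. Statements on the series, on what has been measured and on what is new or still open speak of the compounds shown alone.

Measured compounds in a functional assay on MCF7 cells (Homo sapiens) for antiproliferative activity, read by MTT assay; a higher number here means a weaker inhibitor, a lower number a stronger inhibitor:

Compound 1 `NS(=O)(=O)c1ccc(N/N=C(/CS(=O)(=O)c2ccccc2)c2ccc(Br)cc2)cc1` gives 17300 nM.
Compound 2 `NS(=O)(=O)c1ccc(N/N=C(/CS(=O)(=O)c2ccccc2)c2ccc(Cl)cc2)cc1` gives 8010 nM.
Compound 3 `NS(=O)(=O)c1ccc(N/C=C(\C(=O)c2ccc(Br)cc2)S(=O)(=O)c2ccccc2)cc1` gives 62700 nM.

Compounds 1 and 2 differ in one place only, (chloro in place of bromo on an aromatic carbon). This change gave a 2.2-fold lower number from compound 1 to compound 2 (0.33 log units; beyond the scatter). Compound 3 has the highest number of the three; the difference between its core and the core of compound 1 is not broken down here.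

Compound 4 `NS(=O)(=O)c1ccc(N/C=C(\C(=O)c2ccc(Cl)cc2)S(=O)(=O)c2ccccc2)cc1` is not yet measured. It differs from compound 3 by chloro in place of bromo on an aromatic carbon, the same change as that from compound 1 to compound 2, made at a place described in the same words. Only one earlier instance of this change exists among these compounds, so the expectation rests on a single pair. Because compound 2 gave 8010 nM against compound 1, a comparable move is expected here, that is a 2.1-fold lower number from compound 3 to compound 4 (0.32 log units; beyond the scatter), with wider uncertainty since the core of compound 3 sits at a weaker level. In this assay compound 4 is estimated at 30000 nM, expected between 14000 nM and 65000 nM.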

Compound 4, half-maximal inhibitory concentration: 15100 nM
Beside the measured number, compound 4's estimate is 2.0-fold (0.30 log units) above it; the measured number falls inside the stated range.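

In this assay, chloro in place of bromo on an aromatic carbon gave a 4.2-fold lower number from compound 3 to compound 4 (0.62 log units; beyond the scatter) and so moved the number in the same direction on the second core as on the first. Set side by side, the two steps cannot be told apart in size: the same change on two cores in this assay, a 2.2-fold lower number (0.33 log units; beyond the scatter) from compound 1 to compound 2 and a 4.2-fold lower number (0.62 log units; beyond the scatter) from compound 3 to compound 4, 1.9-fold (0.28 log units) apart, within the scatter of two such steps

The larger step on the core of compound 3 therefore gives no sign that the core alters the effect of this change, but two pairs show only that direction and rough size held on these two cores, not that they would hold on any other core or why the change acts as it does.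

The compounds shown leave open how the 4-chlorophenyl compares with other groups at this place, such as fluoro, methyl or methoxy. They also leave open whether the same step would appear with a carboxylic acid in place of the sulfonamide on either core.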